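From 4-Methyl to 4,4-Dimethyl on a Shared Core

This account rests on a few compounds, and the source may have more. Where it says the series, first, only, none or still open, it means among the compounds named here.

In a physicochemical assay for solubility, read by LC-MS, in phosphate buffer, with a stated time of 24 h, at pH 7.4 (a lower number here means a less soluble compound, a higher number a more soluble compound), compound 1 `Fc1ccc2c(c1CNc1ncc(Oc3ccccc3)c3nncn13)CCO2` gives 8000 nM and compound 2 `C[C@@H]1CC(=O)N(c2cnc(NCc3c(F)ccc4c3CCO4)n3cnnc23)C1` gives 130000 nM as the higher of the two numbers. Among the measured compounds shown here, the only measured step is a 16-fold higher number from compound 1 to compound 2 (1.21 log units; beyond the scatter) and it is large, but it swapped phenoxy for 4-methyl-2-oxopyrrolidin-1-yl, a different change from the one considered here. Compound 3 `CC1(C)CC(=O)N(c2cnc(NCc3c(F)ccc4c3CCO4)n3cnnc23)C1` carries 4,4-dimethyl-2-oxopyrrolidin-1-yl in place of 4-methyl-2-oxopyrrolidin-1-yl on an aromatic carbon of the shared core. For the measured compounds named here, no measured step covers this change, so the expected step is a 1.3-fold lower number from compound 2 to compound 3 (0.11 log units; within the scatter) and it stays within the scatter. Compound 3 is estimated at 100000 nM with a range from 40000 nM to 200000 nM in this read-out.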

Compound 3, solubility: 57000 nM
For compound 3 the middle estimate is 1.8-fold (0.24 log units) above the measured one; measured number inside the range.
By their numbers in this assay, from the lowest: compound 1; then compound 3; then compound 2.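

In this assay, 4,4-dimethyl-2-oxopyrrolidin-1-yl in place of 4-methyl-2-oxopyrrolidin-1-yl gives a 2.3-fold lower number from compound 2 to compound 3 (0.36 log units; beyond the scatter), so even a change this small within the ring registers on this aromatic carbon. Against phenoxy, the dimethyl ring still shows a 7.1-fold higher number from compound 1 to compound 3 (0.85 log units; beyond the scatter), which keeps part of the rise seen with the 4-methyl ring. Nothing available explains why the added methyl lowers the number. Still open, from the compounds shown here alone, is how the same carbon would read with the plain 2-oxopyrrolidin-1-yl ring, without any methyl, or with an amine such as morpholin-4-yl.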